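This account rests on a few compounds, and the source may have more. Where it says the series, first, only, none or still open, it means among the compounds named here.

Compound 1, `CN1CC(c2ccc(C(F)(F)F)cc2)(C(O)c2ccccn2)C1`: in an ADME assay on liver for metabolic stability, with Liver microsome (Rattus norvegicus) as the target, read by LC-MS, using microsomes, with a stated time of 5 h (a lower number here means slower removal, a higher number faster removal of the compound), compound 1 gives 117 mL/min/kg.
Compound 2, `OC(c1ccc(F)cn1)C1(c2ccc(Cl)c(Cl)c2)CCC1`: in this assay compound 2 gives 3170 mL/min/kg.

Compound 2 stands highest of the two numbers in this assay; the nearest is compound 1, whose number is a good deal lower, and that gap lies beyond the usual scatter. Compound 3, `OC(c1cc(F)ccn1)C1(c2ccc(Cl)c(Cl)c2)CCC1`, has not yet been measured. It differs from compound 2 in one place: 4-fluoropyridin-2-yl in place of 5-fluoropyridin-2-yl on a saturated chain carbon bound to an oxygen on a saturated carbon and a saturated ring carbon. The two share the same atoms, joined differently. Going by the values given here, no pair of measured compounds differs in just this way, so there is no measured step to lean on. The change only moves the fluorine to another spot on the same ring, so no step beyond the scatter is expected in this assay, in either direction. Compound 3 is expected to give about 2800 mL/min/kg in this assay, within 1300 mL/min/kg to 6000 mL/min/kg. That expectation means an estimated step of a 1.1-fold lower number from compound 2 to compound 3 (0.05 log units; within the scatter) that stays within the scatter.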

Compound 3, clearance: 3850 mL/min/kg
For compound 3 the middle estimate is 1.4-fold (0.14 log units) below the measured one, and the stated range covers the measured number.
By their numbers in this assay, from the lowest: compound 1; then compounds 2 and 3 (each within the scatter of the next).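

Moving the fluorine from 5-fluoropyridin-2-yl to 4-fluoropyridin-2-yl gives a 1.2-fold higher number from compound 2 to compound 3 (0.08 log units; within the scatter) in this assay and is the first measured step at this position, on a saturated chain carbon bound to an oxygen on a saturated carbon and a saturated ring carbon. For this pair, the place of the fluorine on the pyridine ring makes no difference to clearance that can be told apart from the scatter of repeated measurements. Nothing on hand gives a reason for this result. The two fluorine placements say nothing about how clearance in this assay would respond if a different group, such as a nitrile or a methoxy group, took the place of the fluorine on this ring. As far as these compounds go, whether a step beyond the scatter can arise at this position at all remains open.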